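From ethyl to 4-hydroxyphenyl on the shared core

A few compounds are considered here, and "the series" means these few. Any claim that something is new, unique, unknown or untested is made for them only; others in the source may bear on it.

In a functional assay on SMMC-7721 cells (Homo sapiens) for cytotoxicity, read by MTT assay, with a stated time of 72 h (on this read-out lower numbers stand for stronger inhibition and higher numbers for weaker inhibition), compound 1 (`CCC(C)=C1C(=O)N(c2ccc(Cl)cc2)N(c2ccc(Cl)cc2)C1=O`) gives 49200 nM and compound 2 (`COc1cccc(C=C2C(=O)N(c3ccc(Cl)cc3)N(c3ccc(Cl)cc3)C2=O)c1`) gives 30200 nM, and these two values lie within the usual scatter of each other. Compound 3 (`CC(=C1C(=O)N(c2ccc(Cl)cc2)N(c2ccc(Cl)cc2)C1=O)c1ccc(O)cc1`) has 4-hydroxyphenyl in place of ethyl on a double-bonded chain carbon bound to a double-bonded ring carbon and a saturated chain carbon. For the measured compounds named here, no measured step isolates this change. Only a small step towards lower numbers is expected in this assay (a 2.0-fold lower number from compound 1 to compound 3 (0.29 log units; within the scatter)), possibly none beyond the scatter. For compound 3 the expected value is 25000 nM (estimated range 8000 nM to 70000 nM).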

Compound 3, half-maximal inhibitory concentration: 57000 nM
Estimate against measurement, compound 3: 2.3-fold (0.36 log units) below; the range from low to high includes it.
By their numbers in this assay, from the lowest: compounds 2, 1 and 3 (each within the scatter of the next).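

In this assay, the exchange at this double-bonded chain carbon is a large one in what is counted, as a six-membered aromatic ring and a hydrogen-bond donor enter, yet it amounts only to a 1.2-fold higher number from compound 1 to compound 3 (0.06 log units; within the scatter). At this position, ethyl and 4-hydroxyphenyl are therefore not separated by the read-out. Nothing available explains this result.

As far as these compounds go, it remains open whether the hydroxyl of the 4-hydroxyphenyl contributes anything on its own. From the compounds shown here alone, it is also open whether an amine or a carboxylic acid on that ring, or a longer chain in place of ethyl, would give a step beyond the scatter.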